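The compounds below may be only part of what the source reports. "The series", "measured", "known", "first", "only" and "open" are said of these compounds alone.

The three measured compounds share one core and differ only in what the aromatic ring of the benzyl arm carries. In a functional assay on MGC-803 cells (Homo sapiens) for antiproliferative activity, read by MTT assay, with a stated time of 48 h (on this read-out lower numbers stand for stronger inhibition and higher numbers for weaker inhibition), compound 1 `COc1ccc(CN(C(=O)CSc2nc3ccccc3s2)c2cc(OC)c(OC)c(OC)c2)cc1N` gives 84 nM. Compound 2 `COc1ccc(CN(C(=O)CSc2nc3ccccc3s2)c2cc(OC)c(OC)c(OC)c2)cc1C(F)(F)F` gives 25200 nM. Compound 3 `COc1ccc(CN(C(=O)CSc2nc3ccccc3s2)c2cc(OC)c(OC)c(OC)c2)cc1[N+](=O)[O-]` gives 682 nM. Compound 3 therefore stands second highest of the three numbers, closer to compound 1 than to compound 2: an 8.1-fold higher number from compound 1 to compound 3 (0.91 log units; beyond the scatter), whereas a 37-fold lower number from compound 2 to compound 3 (1.57 log units; beyond the scatter). Compound 4 `COc1cc(N(Cc2ccc(Cl)cc2)C(=O)CSc2nc3ccccc3s2)cc(OC)c1OC` has not yet been measured. It differs from compound 3 in that (4-chlorophenyl in place of 4-methoxy-3-nitrophenyl on a saturated chain carbon bound to an amide-type nitrogen). Among the measured compounds shown here, every recorded step alters a single group on this same ring, and a 300-fold higher number from compound 1 to compound 2 (2.48 log units; beyond the scatter) shows how strongly those groups govern the result; yet no step removes both the methoxy and the nitro or brings in chlorine, so the direction is open. A change of some size is expected, plausibly toward a higher number, though a lower one cannot be excluded. For compound 4 the expected step is a 2.2-fold higher number from compound 3 to compound 4 (0.34 log units; beyond the scatter). Compound 4 is thus estimated to give about 1500 nM in this assay, within 150 nM to 15000 nM.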

Compound 4, half-maximal inhibitory concentration: > 80000 nM
Compound 4 gave a limit, no number; the forecaster's own chance of this, stated with the estimate: 5%; middle value at least 53-fold (1.72 log units) from the limit.
By their numbers in this assay, from the lowest: compound 1; then compound 3; then compound 2. At a limit, above all of these: compound 4.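

In this assay, compound 4 returns only a limit and not a number: the limit of > 80000 nM in this assay, at which 1 of the 4 values shown sits. The earlier compounds shown here exchanged one group on the benzyl arm while the methoxy stayed, whereas 4-chlorobenzyl replaces the whole substitution pattern, and the result is an at least 110-fold higher number from compound 3 to compound 4 (2.06 log units; beyond the scatter), an at least 950-fold higher number from compound 1 to compound 4 (2.97 log units; beyond the scatter) and even an at least 3.1-fold higher number from compound 2 to compound 4 (0.50 log units; beyond the scatter). So this position tolerates the change to 4-chlorophenyl less well than any group swap seen so far, and compound 2, previously the highest number, no longer marks the upper end of the series.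

The compounds shown leave open whether the loss of the methoxy, the loss of the nitro or the arrival of chlorine carries this step, since all three happen at once. As far as these compounds go, how an arm keeping only the methoxy, or one with bromine or hydroxyl in place of chlorine, would compare also remains open.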